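The source may hold more compounds than are shown below. What is called first, only, known or untested is meant among the compounds shown, and "the series" means these compounds.

Going by the values given here, compound 2 `CCOC(=O)c1cnc(N2CCN(Cc3ccc(C(N)=O)cc3)CC2)nc1Oc1c(C)cc(-c2ccc(C#N)cc2)cc1C` is the only compound with a number in an ADME assay on MT4 cells (Homo sapiens) for cytotoxicity, read by MTT assay, with a stated time of 4 days (a higher number here means that more compound is tolerated, a lower number that less compound is tolerated), where compound 2 gives 66500 nM. Compound 1 `CCOC(=O)c1cnc(N2CCN(Cc3ccccc3C(F)(F)F)CC2)nc1Oc1c(C)cc(-c2ccc(C#N)cc2)cc1C` reaches only a limit of this assay, at > 125000 nM. Among the compounds with values here, the single measured step, an at least 1.8-fold lower number from compound 1 to compound 2 (0.27 log units; that floor lies within the scatter), sits on that limit of > 125000 nM in this assay, at which 1 of the 2 values shown sits, and concerns a different group, so it carries little for a positional swap of the carbamoyl group. Compound 3 `CCOC(=O)c1cnc(N2CCN(Cc3cccc(C(N)=O)c3)CC2)nc1Oc1c(C)cc(-c2ccc(C#N)cc2)cc1C` differs from compound 2 by 3-carbamoylphenyl in place of 4-carbamoylphenyl on a saturated chain carbon bound to an amine nitrogen in a ring. Within the data shown here, no measured step bears on this change, and no step beyond the scatter is expected in this assay. Compound 3 is therefore estimated at 66500 nM, with a range from 30000 nM to 140000 nM. This estimate means a step of no change at the digits printed from compound 2 to compound 3 (within the scatter).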

Compound 3, half-maximal cytotoxic concentration: 14800 nM
Compound 3: the middle estimate sits 4.5-fold (0.65 log units) above what was measured, outside the stated range (below it).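

In this assay, the swap of 4-carbamoylphenyl for 3-carbamoylphenyl is not neutral: the two groups have the same atoms joined differently, yet the result is a 4.5-fold lower number from compound 2 to compound 3 (0.65 log units; beyond the scatter). The tolerated concentration at this place therefore depends on where the carbamoyl group sits on the phenyl ring, not only on which group is present. Against the 2-(trifluoromethyl)phenyl compound, the result is an at least 8.4-fold lower number from compound 1 to compound 3 (0.92 log units; beyond the scatter), and this step starts from a limit of compound 1: the limit of > 125000 nM in this assay, at which 1 of the 3 values shown sits.

Still open, on these data alone, is how 2-carbamoylphenyl would read here. As far as these compounds go, a carboxylic acid or an amine in place of the carbamoyl group also remains open.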